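Compound 1 to compound 3: chloro on the phenyl

The source may hold more compounds than are shown below. What is called first, only, known or untested is meant among the compounds shown, and "the series" means these compounds.

In a functional assay on HCT-116 cells (Homo sapiens) for inhibition, read by MTT assay, with a stated time of 72 h (a higher number here means a weaker inhibitor of growth, a lower number a stronger inhibitor of growth), compound 1 (`CN(C)c1ccc(-c2nc3c(N4CCN(CC(=O)Nc5ccccc5)CC4)c(Cl)cnc3[nH]2)cc1`) gives 2550 nM and stands highest of the two numbers in hand. Compound 2 (`Cc1cc(CN2CCN(c3c(Cl)cnc4[nH]c(N5CCN(C)CC5)nc34)CC2)no1`) gives 140 nM in the same read-out, a gap beyond the scatter, which makes compound 1 the weaker inhibitor of growth of the two. Compound 3 (`CN(C)c1ccc(-c2nc3c(N4CCN(CC(=O)Nc5cccc(Cl)c5)CC4)c(Cl)cnc3[nH]2)cc1`) keeps everything in compound 1 except that phenyl becomes 3-chlorophenyl (chloro in place of hydrogen on an aromatic carbon), chloro in place of hydrogen on an aromatic carbon. Within the data shown here, no measured pair isolates this change, so the expectation rests on the change alone. Only a small step is expected in this assay, toward a lower number, and none clearly beyond the scatter. The estimated move is a 1.4-fold lower number from compound 1 to compound 3 (0.15 log units; within the scatter) and no larger shift is expected. For compound 3 the estimated value is 1800 nM with an expected range from 700 nM to 4000 nM in this read-out.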

Compound 3, concentration for 50% growth inhibition: 2670 nM
Compound 3: middle estimate off by 1.5-fold (0.17 log units), on the low side; the range from low to high includes it.
By their numbers in this assay, from the lowest: compound 2; then compounds 1 and 3 (each within the scatter of the next).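

Chloro in place of hydrogen on an aromatic carbon of the phenyl, meta to a large group, gives a 1.0-fold higher number from compound 1 to compound 3 (0.02 log units; within the scatter) in this assay, the first single-place step in the series. At this place on the phenylcarbamoyl arm, the added chlorine leaves compound 1 and compound 3 indistinguishable in this read-out, so the phenyl accepts this one heavy atom with no step beyond the scatter. Nothing available bears on why this substitution leaves the read-out where it is.

From the compounds shown here alone, whether a methoxy, an amine or a carboxylic acid at the same place would read the same remains open, as does chloro elsewhere on the phenyl. Compound 2 differs from compound 1 in more than one place, so the contribution of any single group cannot be read from that pair.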